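The source may report more compounds than this note shows. Statements on the series, on what has been measured and on what is new or still open speak of the compounds shown alone.

The series is followed in a functional assay on CHO cells for agonist activity at Free fatty acid receptor 1 (Homo sapiens); on this read-out higher numbers stand for an effect only at larger amounts of compound and lower numbers for an effect already at smaller amounts. Compound 1, `NC(=O)CCc1ccc(NCc2cccc(Oc3ccccc3)c2)cc1`, gives 51.3 nM in this assay. Compound 3, `CC(C)NC(=O)CCc1ccc(NCc2cccc(Oc3ccccc3)c2)cc1`, carries the change isopropyl in place of hydrogen on an amide-type nitrogen relative to compound 1, and in this assay compound 3 gives 39.8 nM. The step of a 1.3-fold lower number from compound 1 to compound 3 (0.11 log units; within the scatter) is a small one, and the two numbers are best read as equivalent.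

Compound 2, `Cc1nc(-c2ccc(C(F)(F)F)cc2)sc1CNc1ccc(CCC(N)=O)cc1`, rests on a different core; how the two cores differ is not broken down here. In this assay compound 2 gives 12.9 nM, the lowest of the three numbers, with compound 3 as its nearest neighbour and compound 1 furthest away, both gaps lying beyond the usual scatter.

Compound 4, `Cc1nc(-c2ccc(C(F)(F)F)cc2)sc1CNc1ccc(CCC(=O)NC(C)C)cc1`, has not yet been measured. It stands to compound 2 as compound 3 stands to compound 1: the change (isopropyl in place of hydrogen on an amide-type nitrogen), at a place described in the same words as for the earlier pair, so that the change counts as the same one, occurring twice among these compounds.

Within the data shown here, the only guide is the earlier pair, where the same change produced a 1.3-fold lower number from compound 1 to compound 3 (0.11 log units; within the scatter), a step within the scatter. On that basis compound 4 is expected to sit close to compound 2, with an estimated step of a 1.3-fold lower number from compound 2 to compound 4 (0.11 log units; within the scatter). Compound 4 is therefore estimated to give 10 nM in this assay, with the expected range running from 4 nM to 25 nM.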

Compound 4, half-maximal effective concentration: 100 nM
For compound 4 the middle estimate is 10-fold (1.00 log units) below the measured one; the whole stated range lies below it.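

On the core of compound 2, isopropyl in place of hydrogen on the amide-type nitrogen produces a 7.8-fold higher number from compound 2 to compound 4 (0.89 log units; beyond the scatter) in this assay, so here the change has a clear effect on the read-out, whereas on the core of compound 1 its step stayed within the scatter. Set side by side, the two steps disagree, which means that the size of this change did not carry over from one core to the other: the same change on two cores in this assay, a 1.3-fold lower number (0.11 log units; within the scatter) from compound 1 to compound 3 and a 7.8-fold higher number (0.89 log units; beyond the scatter) from compound 2 to compound 4, 10-fold (1.00 log units) apart, beyond the scatter of two such steps. This shows that, for these two pairs, the outcome of the change depends on the core it sits on, but it does not show which part of the cores matters, why the steps differ, or how the change would behave on any further core.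

The compounds shown leave open whether the larger step on the core of compound 2 belongs to isopropyl in particular or would also appear with methyl, ethyl or cyclopropyl on the same nitrogen. They also leave open whether a carboxylic acid in place of the amide would show the same dependence on the core, and which of the features that separate the two cores accounts for the difference.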